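Three Sulfur-Linked Enones and an Untested Fourth

The compounds below may be only part of what the source reports. "The series", "measured", "known", "first", "only" and "open" are said of these compounds alone.

For the measured compounds named here, the three compounds tested so far share a chalcone-like core with a sulfur-linked substituent on the double bond. Compound 1 `COc1ccc(/C=C(\C(=O)c2ccc(Cl)cc2)S(=O)(=O)Cc2ccccc2Cl)cc1` carries a sulfonyl link; in a functional assay on DU-145 cells (Homo sapiens) for inhibition, read by trypan blue exclusion, with a stated time of 96 h (a higher number here means a weaker inhibitor of growth, a lower number a stronger inhibitor of growth), compound 1 gives 50000 nM. Compound 2 `O=C(/C(=C\c1ccc(Cl)cc1Cl)Sc1ccc(Br)cc1)c1ccc(Br)cc1`, with a thioether link, gives 1000 nM in this assay, and compound 3 `Cc1ccc(S/C(=C/c2c[nH]c3ccccc23)C(=O)c2ccc(Cl)cc2)cc1`, also a thioether, gives 10000 nM. On these numbers compound 1 stands highest, that is weakest, with compound 3 the nearest of the other two and compound 2 the furthest, both gaps beyond the scatter.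

Compound 4 `CCOc1ccc(/C=C(\C(=O)c2ccc(Cl)cc2)S(=O)(=O)Cc2ccccc2Cl)cc1OC` has not been measured. It differs from compound 1 in one place: 4-ethoxy-3-methoxyphenyl in place of 4-methoxyphenyl on a double-bonded chain carbon bound to a double-bonded chain carbon. The sulfonyl link and the rest of the core of compound 1 stay as they are.

Going by the values given here, no measured pair shows this kind of change, so there is nothing to calibrate its size. Because compound 1 already sits at 50000 nM, and the two thioether compounds differ from it in another place altogether, the step is expected to be small, within the scatter, with at most a slight move toward a lower number: a 1.4-fold lower number from compound 1 to compound 4 (0.15 log units; within the scatter) is the expectation. Compound 4 is estimated at 35000 nM, with a likely range from 10000 nM to 100000 nM.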

Compound 4, concentration for 50% growth inhibition: 10000 nM
For compound 4 the middle estimate is 3.5-fold (0.54 log units) above the measured one, and the stated range covers the measured number.
By their numbers in this assay, from the lowest: compound 2; then compounds 3 and 4 (each within the scatter of the next); then compound 1.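

For the compounds shown here, this is the first change in the set that can be read in one place only. In this assay, 4-ethoxy-3-methoxyphenyl in place of 4-methoxyphenyl gives a 5.0-fold lower number from compound 1 to compound 4 (0.70 log units; beyond the scatter) with the sulfonyl link and the rest of the core of compound 1 unchanged. Going by these compounds alone, the step is modest, but it shows that the group on a double-bonded chain carbon bound to a double-bonded chain carbon can move the number by itself, something the earlier compounds, with no single-place pair among them, could not show. Nothing given here accounts for the step.

The change swaps one group for another that differs in two respects, so the compounds shown do not separate what the ethoxy chain contributes from what the added methoxy contributes. They also leave open whether a longer chain such as butoxy, or an amine or a carboxylic acid on this phenyl ring, would lower the number further, and whether the same swap would have any comparable effect on a compound with a thioether link.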